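Chain shortening in a diamine series: expected lipophilicity shift

The compounds below may be only part of what the source reports. "The series", "measured", "known", "first", "only" and "open" are said of these compounds alone.

Measured compounds:
compound 1, `CCCCCCCCCCCCNCCCN` — in a physicochemical assay for lipophilicity (on this read-out higher numbers stand for higher lipophilicity and lower numbers for lower lipophilicity), compound 1 gives 5.06
compound 2, `CCCCCCCCCCC(O)CNCCO` — in this assay compound 2 gives 3.62

Compound 1 stands highest of the two numbers in this assay; the nearest is compound 2, whose value lies lower by a gap beyond the scatter. Among the measured compounds shown here, the two measured compounds differ in more than one place, so no single step between them is counted and their values are simply set side by side.

Compound 3, `CCCCCCCCCCNCCCN`, is not yet measured. Against compound 1 the change is hydrogen in place of ethyl on a saturated chain carbon, ten or more bonds along the chain from an amine nitrogen. For the measured compounds named here, no measured pair maps this kind of step, so the expectation rests on compound 1 alone, whose value of 5.06 is the starting point. A downward step of moderate size, beyond the scatter, is expected, reading a number 1.01 log units lower from compound 1 to compound 3 (beyond the scatter). For compound 3 the estimated value in this assay is 4.05, with a range from 3.5 to 4.6.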

Compound 3, partition coefficient: 2.82
Compound 3: middle estimate off by 1.23 log units, on the high side, outside the stated range (below it).
By their numbers in this assay, from the lowest: compound 3; then compound 2; then compound 1.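

Replacing ethyl with hydrogen on a saturated chain carbon gives a number 2.24 log units lower from compound 1 to compound 3 (beyond the scatter) in this assay, a large step. Among the compounds shown here, this is the first single-place step, and it shows that this position, far along the chain from the amine nitrogen, is not silent on this read-out: the change moves the number well beyond the scatter. Nothing at hand accounts for the size of this step.

Going by these compounds, one step gives no slope, so it remains open whether the value changes evenly along the chain or more sharply over part of it. Methyl at this place, or a longer chain than that of compound 1, would show how the values run on either side of this step.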